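Replacing the chloroalkyl carbonyl chain of compound 2

A few compounds are considered here, and "the series" means these few. Any claim that something is new, unique, unknown or untested is made for them only; others in the source may bear on it.

Within the data shown here, compound 2 `O=C(CCCCl)Nc1ccc(S(=O)(=O)Oc2ccccc2I)cc1` gives 9100 nM in a functional assay on HT-29 cells (Homo sapiens) for antiproliferative activity, read by sulforhodamine B assay, with a stated time of 48 h (on this read-out lower numbers stand for stronger inhibition and higher numbers for weaker inhibition), the highest of the two numbers measured so far; its nearest neighbour, compound 1 `O=C(CCl)Nc1ccc(S(=O)(=O)Oc2ccccc2I)cc1`, gives 4100 nM, and the only measured step, a 2.2-fold higher number from compound 1 to compound 2 (0.35 log units; beyond the scatter), lengthens the chloroalkyl chain. Compound 3 `CCCNC(=O)Nc1ccc(S(=O)(=O)Oc2ccccc2I)cc1` carries the change (propylamino in place of 3-chloropropyl on a carbonyl carbon), so the chlorine leaves altogether and a propylcarbamoyl group takes the place of the (3-chloropropyl)carbonyl. Among the measured compounds shown here, no measured step covers this change; the step from compound 1 to compound 2 concerns chain length only and says nothing about removing chlorine or bringing in a hydrogen-bond donor. With both measured numbers already high and no guide in either direction, the number for compound 3 is expected near that of compound 2, a step of a 1.3-fold higher number from compound 2 to compound 3 (0.12 log units; within the scatter) with wide uncertainty. Compound 3 is estimated at 12000 nM, between 4000 nM and 40000 nM.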

Compound 3, half-maximal inhibitory concentration: 6800 nM
For compound 3 the middle estimate is 1.8-fold (0.25 log units) above the measured one, within the range that was stated.
By their numbers in this assay, from the lowest: compounds 1, 3 and 2 (each within the scatter of the next, the first and the last beyond it).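

Placing propylamino in place of 3-chloropropyl on the carbonyl carbon gives a 1.3-fold lower number from compound 2 to compound 3 (0.13 log units; within the scatter), and propylamino in place of chloromethyl gives a 1.7-fold higher number from compound 1 to compound 3 (0.22 log units; within the scatter). In this assay, the chlorine of the chain can therefore be absent, and the hydrogen-bond donor of propylamino present, without a change beyond the scatter from either chlorinated compound. No measurement here accounts for this result.

The compounds shown leave open how much the loss of chlorine and the entry of the amino nitrogen each contribute, since the two changes occur together; a plain propyl group on the carbonyl carbon would separate them. Also open, as far as these compounds go, is whether a longer alkylamino chain, a cyclic amine or a terminal carboxylic acid would move the number beyond the scatter.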